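This account rests on a few compounds, and the source may have more. Where it says the series, first, only, none or still open, it means among the compounds named here.

Measured to date:
- compound 1, `O=c1[nH]c2ccc(Cl)cc2c(-c2ccccc2Cl)c1CCO`, 380000 nM in an ADME assay on HepG2 2.2.15 cells (Homo sapiens) for cytotoxicity; on this read-out lower numbers stand for higher toxicity in this test and higher numbers for lower toxicity in this test
- compound 2, `C=CCn1c(=O)c(CCO)c(-c2ccccc2Cl)c2cc(Cl)ccc21`, 23000 nM
- compound 3, `CCCCC(=O)OCCc1c(-c2ccccc2Cl)c2cc(Cl)ccc2[nH]c1=O`, 200000 nM

Compound 3 sits second highest of the three numbers in this assay. Its nearest neighbour is compound 1, and the separation between them, a 1.9-fold lower number from compound 1 to compound 3 (0.28 log units; within the scatter), lies within the scatter, so the two cannot be ordered. Compound 2 stands furthest away with a markedly lower number.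

Compound 4, `CC(=O)N1CCC(C(=O)OCCc2c(-c3ccccc3Cl)c3cc(Cl)ccc3[nH]c2=O)CC1`, is not yet measured. It differs from compound 3 at the ester: 1-acetylpiperidin-4-yl in place of butyl on a carbonyl carbon. For the measured compounds named here, the only measured step at this part of the molecule is the one from a free hydroxyl to the ester of compound 3, a 1.9-fold lower number from compound 1 to compound 3 (0.28 log units; within the scatter), which stayed within the scatter. The large step of a 17-fold lower number from compound 1 to compound 2 (1.22 log units; beyond the scatter) concerns the aromatic nitrogen and does not bear on the present change. Going by the values given here, no measured step reports what an acetylpiperidinyl carbonyl does here, so the expectation rests on the quiet ester step alone: no movement beyond the scatter is expected, no change at the digits printed from compound 3 to compound 4 (within the scatter). Compound 4 is therefore estimated at 200000 nM, with a range from 70000 nM to 600000 nM.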

Compound 4, half-maximal cytotoxic concentration: 82000 nM
Compound 4: the middle estimate sits 2.4-fold (0.39 log units) above what was measured; low and high end bracket the measured number.
By their numbers in this assay, from the lowest: compound 2; then compound 4; then compounds 3 and 1 (each within the scatter of the next).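

In this assay the acyl group on the ester oxygen now makes a difference: exchanging butyl for 1-acetylpiperidin-4-yl on the carbonyl carbon gives a step beyond the scatter (a 2.4-fold lower number from compound 3 to compound 4 (0.39 log units; beyond the scatter)), whereas the butylcarbonyl ester could not be separated from the free hydroxyl. Against that free hydroxyl, the (1-acetylpiperidin-4-yl)carbonyl ester also moves beyond the scatter (a 4.6-fold lower number from compound 1 to compound 4 (0.67 log units; beyond the scatter)), so among these compounds the number depends on which acyl group is present and not merely on the ester being there. Nothing at hand gives a reason for this shift.

The compounds shown do not separate the piperidine ring from its acetyl group. A piperidin-4-yl carrying a free amine, a cyclohexyl ring or a longer straight chain on the same carbonyl would each test one part of the change.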